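Swapping Nitro for Fluoro in Compound 1

A few compounds are considered here, and "the series" means these few. Any claim that something is new, unique, unknown or untested is made for them only; others in the source may bear on it.

Compound 1 `C/C=C/C(=O)N(Cc1ccc(OC)c([N+](=O)[O-])c1)c1cc(OC)c(OC)c(OC)c1`: 510 nM
Compound 2 `COc1cc(NCc2cccc(O)c2)cc(OC)c1OC`: 71300 nM

In a functional assay on KYSE-450 cells (Homo sapiens) for inhibition, read by MTT assay, with a stated time of 48 h (on this read-out higher numbers stand for weaker inhibition and lower numbers for stronger inhibition), compound 1 gives 510 nM, the lowest of the two numbers. Compound 2 gives 71300 nM, a gap far beyond the usual scatter. Among the measured compounds shown here, no step between measured compounds that differ in a single place is available, so nothing measured bears directly on the change at hand. Compound 3 `C/C=C/C(=O)N(Cc1ccc(OC)c(F)c1)c1cc(OC)c(OC)c(OC)c1` differs from compound 1 in one place: fluoro in place of nitro on an aromatic carbon. Compound 3 is expected to move little, by a step of a 1.4-fold higher number from compound 1 to compound 3 (0.14 log units; within the scatter), not beyond the scatter in either direction. In this assay compound 3 is estimated at 700 nM, within 150 nM to 3500 nM.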

Compound 3, half-maximal inhibitory concentration: 1400 nM
The estimate for compound 3 lay 2.0-fold (0.30 log units) below the measured number, within the range that was stated.
By their numbers in this assay, from the lowest: compound 1; then compound 3; then compound 2.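

In this assay, this aromatic carbon, ortho to a methoxy group, proves sensitive to the group it carries: fluoro in place of nitro gives a 2.7-fold higher number from compound 1 to compound 3 (0.44 log units; beyond the scatter). The step is modest, so inhibition does not depend wholly on nitro, although nitro gives the lower number of the two. Nothing at hand explains this difference. The compounds shown leave open how an amine, a nitrile or a chloro group on this carbon would compare with nitro and fluoro. This single step also cannot show whether the same change would act alike on another core.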